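Swapping bromophenyl for dichlorophenyl in a weak compound

The source may report more compounds than this note shows. Statements on the series, on what has been measured and on what is new or still open speak of the compounds shown alone.

- compound 1 `O=C(/C=C/c1ccc(F)cc1)Oc1ccc(/C=C2\CCCCC2=O)cc1`: 14400 nM
- compound 2 `O=C(/C=C/c1ccc(Br)cc1)Oc1ccc(/C=C2\CCCCC2=O)cc1`: 131000 nM

In a functional assay on CCRF-CEM cells (Homo sapiens) (a lower number here means a stronger inhibitor, a higher number a weaker inhibitor), compound 2 has the higher number of the two at 131000 nM, which makes it the weaker inhibitor. Compound 3 `O=C(/C=C/c1ccc(Cl)c(Cl)c1)Oc1ccc(/C=C2\CCCCC2=O)cc1` differs from it in one group: 3,4-dichlorophenyl in place of 4-bromophenyl on a double-bonded chain carbon bound to a double-bonded chain carbon. Going by the values given here, only one measured step bears on this change, a swap of one halogen for another, and it is a 9.1-fold higher number from compound 1 to compound 2 (0.96 log units; beyond the scatter). Among the compounds with values here, no measured compound carries 3,4-dichlorophenyl, so the guide is loose, but a modest step towards a lower number is expected. The expected change is a 2.9-fold lower number from compound 2 to compound 3 (0.46 log units; beyond the scatter). Compound 3 is estimated at 45000 nM, within a range of 12000 nM to 160000 nM.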

Compound 3, half-maximal inhibitory concentration: 63800 nM
Compound 3: the middle estimate sits 1.4-fold (0.15 log units) below what was measured, and the stated range covers the measured number.
By their numbers in this assay, from the lowest: compound 1; then compound 3; then compound 2.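

In this assay, the 3,4-dichlorophenyl group wins back only part of the ground lost with 4-bromophenyl: the swap gives a 2.1-fold lower number from compound 2 to compound 3 (0.31 log units; beyond the scatter) but still leaves a 4.4-fold higher number from compound 1 to compound 3 (0.65 log units; beyond the scatter) on the same position. The three groups thus give three distinct numbers on a shared core, with the fluoro compound still lowest. Nothing available explains this order.

Going by these compounds, whether the change comes from having chlorine rather than bromine or from the second halogen stays open. So does how an unsubstituted phenyl, or a phenyl carrying a methoxy group or an amine, would behave here.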